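A Side-Group Swap on a Core Without Measured Toxicity

The compounds below may be only part of what the source reports. "The series", "measured", "known", "first", "only" and "open" are said of these compounds alone.

Of the compounds shown here, three have been tested so far in an ADME assay on HeLa cells (Homo sapiens) for cytotoxicity, read by ATP content, with a stated time of 3 days; on this read-out lower numbers stand for higher toxicity in this test and higher numbers for lower toxicity in this test. Compound 1 `N#CCCCn1c(Cn2c(=O)n(-c3ccc(C(=O)NC4CC4)cc3)c3ccncc32)cc2cc(Cl)ccc21` gave only a limit in this assay, > 50000 nM. Compound 2 `COc1ccc2c(c1)cc(Cn1c(=O)n(C3CC3)c3ccncc31)n2CCCCO` likewise gave a limit, > 50000 nM. Compound 3 `CC(C)CCn1c(Cn2c(=O)n(C3CC3)c3ccncc32)nc2ncccc21` also gave a limit, > 100000 nM. Compound 1 therefore stands at the limit of > 50000 nM in this assay, at which 2 of the 3 values shown sit, while the remaining value is the limit of > 100000 nM in this assay, at which 1 of the 3 values shown sits. No two of these compounds differ in a single place, so no measured step between them is available.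

Compound 4 `COc1ccc(-n2c(=O)n(Cc3cc4cc(Cl)ccc4n3CCCC#N)c3cnccc32)c(F)c1` has not yet been measured. It differs from compound 1 in one way (2-fluoro-4-methoxyphenyl in place of 4-(cyclopropylcarbamoyl)phenyl on an aromatic nitrogen). All three measured compounds carry quite different side groups and yet all sit at a limit. On that basis no change beyond the scatter is expected, and the step from compound 1 to compound 4 is estimated as a number no higher from compound 1 to compound 4 (the limit leaves the size open). Compound 4 is expected to give about 50000 nM, with a range from 20000 nM to 120000 nM, and most likely only a limit again.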

Compound 4, half-maximal cytotoxic concentration: > 50000 nM
Compound 4: only a limit was reported (the forecaster's own chance of this, stated with the estimate: 75%); the middle value lies on the limit itself.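

Compound 1 and compound 4 each gave only a limit, so the step between them cannot be read. The compounds shown leave open at what concentration any of them would turn toxic to these cells, and whether swapping this side group changes that concentration at all.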